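The source may report more compounds than this note shows. Statements on the series, on what has been measured and on what is new or still open speak of the compounds shown alone.

Measured in a physicochemical assay for solubility, using the shake flask method, in simulated intestinal fluid, measured as kinetic solubility, with a stated time of 2 h, at 25 degrees C, at pH 6.5; a lower number here means a less soluble compound, a higher number a more soluble compound:
Compound 1 `Cc1noc(-c2nc(C)c3c(c2N)C(=O)N(Cc2ccc(F)cc2)C3=O)n1`: < 5000 nM, a limit
Compound 2 `Cc1noc(-c2nc(C)c3c(c2N)C(=O)N(CC2CCNCC2)C3=O)n1`: 160000 nM
Compound 3 `Cc1noc(-c2nc(C)c3c(c2N)C(=O)N(Cc2ccc(C(F)(F)F)cc2)C3=O)n1`: < 5000 nM, a limit

Compound 3 has no number, only a limit: the limit of < 5000 nM in this assay, at which 2 of the 3 values shown sit. Compound 4 `COc1cccc(CN2C(=O)c3c(C)nc(-c4nc(C)no4)c(N)c3C2=O)c1` carries 3-methoxyphenyl in place of 4-(trifluoromethyl)phenyl on a saturated chain carbon bound to an amide-type nitrogen in a ring. Both groups hold one six-membered aromatic ring of carbon only. The large steps, an at least 32-fold higher number from compound 1 to compound 2 (1.50 log units; beyond the scatter) and an at least 32-fold lower number from compound 2 to compound 3 (1.50 log units; beyond the scatter), both involve piperidin-4-yl, which compound 4 lacks. The closest exchange, a step that the two limits leave unreadable from compound 1 to compound 3, cannot be sized. In this assay, no step beyond the scatter is therefore expected, and the estimated step is a step that the limit leaves unreadable from compound 3 to compound 4. For compound 4 the expected value is 3000 nM, with an estimated range from 1000 nM to 9000 nM.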

Compound 4, solubility: < 5000 nM
Compound 4 was reported as a limit (the forecaster's own chance of this, stated with the estimate: 75%); the middle value is on the limit's open side.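

In this assay compound 4 gives < 5000 nM, a limit. An oxygen-bearing 3-methoxyphenyl at this position therefore reads no differently from the groups of compound 1 and compound 3, which sit at the same limit: the limit of < 5000 nM in this assay, at which 3 of the 4 values shown sit. Compound 2 stands apart, with an at least 32-fold lower number from compound 2 to compound 4 (1.50 log units; beyond the scatter), while the steps joining two limits cannot be read.

As far as these compounds go, how far compound 1, compound 3 and compound 4 lie beneath the limit remains open. So does whether a carboxylic acid on the phenyl ring, or a morpholine in its place, would bring a value above it.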